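Swapping 1-hydroxyethyl for 1,1-difluoroethyl on compound 3

The source may report more compounds than this note shows. Statements on the series, on what has been measured and on what is new or still open speak of the compounds shown alone.

Three related compounds have been measured in an ADME assay on the whole organism (strain 129/SvEvBrd x C57BL/6) for metabolic stability, with Mus musculus as the target; a higher number here means that the compound lasts longer, a lower number that the compound disappears faster. In this assay, compound 1 (`CC(=O)c1ncc([C@@H](O)[C@H](O)[C@H](O)CO)s1`) gives 0.9 h, compound 2 (`CC(=O)c1nc([C@@H](O)[C@H](O)[C@H](O)CO)cn1C`) gives 2.4 h and compound 3 (`CC(O)c1nc([C@@H](O)[C@H](O)[C@H](O)CO)c[nH]1`) gives 4.4 h. Compound 3 stands level with compound 2 within the scatter, and it lies above compound 1 by more than the scatter.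

Compound 4 (`CC(F)(F)c1nc([C@@H](O)[C@H](O)[C@H](O)CO)c[nH]1`) has not yet been measured. It departs from compound 3 in one place: 1,1-difluoroethyl in place of 1-hydroxyethyl on an aromatic carbon. In words, this is 1,1-difluoroethyl in place of 1-hydroxyethyl on an aromatic carbon, between two ring nitrogen atoms.

For the measured compounds named here, no two measured compounds differ in just one place, and the data therefore hold no direct precedent for this change. The expected step is small and stays within the scatter, at an estimated 1.3-fold lower number from compound 3 to compound 4 (0.10 log units; within the scatter). With so little to go on, the range is kept wide. For compound 4 the estimated half-life is 3.5 h, with an expected range of 1.3 h to 9 h.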

Compound 4, half-life: 1 h
Compound 4: the middle estimate sits 3.5-fold (0.54 log units) above what was measured, and the stated range ends above it.
By their numbers in this assay, from the lowest: compounds 1 and 4 (each within the scatter of the next); then compounds 2 and 3 (each within the scatter of the next).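

In this assay, for the compounds shown here, this is the first change in a single place that can be read, and it is not neutral: 1,1-difluoroethyl in place of 1-hydroxyethyl on an aromatic carbon, between two ring nitrogen atoms, gives a 4.4-fold lower number from compound 3 to compound 4 (0.64 log units; beyond the scatter) and so moves the half-life by more than the scatter. The position therefore responds to what it carries, at least for this pair, where the entering group counts 0 hydrogen-bond donors and 0 hydrogen-bond acceptors and the leaving group counts 1 of each. No supporting measurement bears on why the number falls.

From the compounds shown here alone, what an ethyl or a 1-aminoethyl group would give at this position stays open, so removal of the hydroxyl and entry of the two fluorines cannot be told apart. Going by these compounds, whether the same swap would act alike on the core of compound 1 also remains open.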